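Methylsulfanyl in Place of Cyano: Expected Effect

The compounds below may be only part of what the source reports. "The series", "measured", "known", "first", "only" and "open" are said of these compounds alone.

Compound 1 `CCN(CC)c1ccc(NC(=O)c2cn(Cc3c(F)cccc3F)c3ccc(=O)[nH]c3c2=O)cc1` gives 46 nM in an in vitro assay on Sf21 cells for inhibition of high affinity 3',5'-cyclic-AMP phosphodiesterase 7A (Homo sapiens), read by scintillation proximity assay, with a stated time of 30 min; on this read-out higher numbers stand for weaker inhibition and lower numbers for stronger inhibition.
Compound 2 `N#Cc1ccc(NC(=O)c2cn(Cc3c(F)cccc3F)c3ccc(=O)[nH]c3c2=O)cc1` gives 96 nM.
Compound 3 `O=C(O)Cc1ccc(NC(=O)c2cn(Cc3c(F)cccc3F)c3ccc(=O)[nH]c3c2=O)cc1` gives 176 nM.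

These three share one core and differ only in the group on an aromatic carbon of a six-membered aromatic ring of carbon only, para to a large group. On these numbers compound 2 stands second highest of three: the step of a 2.1-fold higher number from compound 1 to compound 2 (0.32 log units; beyond the scatter) lies beyond the scatter, whereas the step of a 1.8-fold higher number from compound 2 to compound 3 (0.26 log units; within the scatter) lies within it. Compound 4 `CSc1ccc(NC(=O)c2cn(Cc3c(F)cccc3F)c3ccc(=O)[nH]c3c2=O)cc1` differs from compound 2 by methylsulfanyl in place of cyano on an aromatic carbon. Both measured steps at this position were small or within the scatter, so only a modest change is expected here. The expected step is a 1.4-fold lower number from compound 2 to compound 4 (0.14 log units; within the scatter), a slightly lower number. Compound 4 is therefore estimated at 70 nM, with a range from 30 nM to 170 nM.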

Compound 4, half-maximal inhibitory concentration: 86 nM
Beside the measured number, compound 4's estimate is 1.2-fold (0.09 log units) below it; the range from low to high includes it.
By their numbers in this assay, from the lowest: compounds 1, 4, 2 and 3 (each within the scatter of the next, the first and the last beyond it).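

In this assay, methylsulfanyl in place of cyano gives a 1.1-fold lower number from compound 2 to compound 4 (0.05 log units; within the scatter), so this swap leaves no change that can be told from the scatter. Among these compounds, the other two steps read a 1.9-fold higher number from compound 1 to compound 4 (0.27 log units; within the scatter) and a 2.0-fold lower number from compound 3 to compound 4 (0.31 log units; beyond the scatter), and only the second of these lies beyond the scatter, so compound 4 adds a sulfur-bearing group to a position where the steps so far stay small or modest. Nothing measured here gives a reason for these steps.

As far as these compounds go, whether a longer alkyl chain or a morpholine ring on this carbon would stay within the same narrow band remains open. So does whether this swap would behave the same way on a different core.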